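The source may report more compounds than this note shows. Statements on the series, on what has been measured and on what is new or still open speak of the compounds shown alone.

Of the compounds shown here, three sharing one core have been measured in a functional assay (B cells) with Mus musculus as the target; a lower number here means that less compound is needed, a higher number that more compound is needed for the effect. Compound 1 `CCCn1c(=O)n(C2OC(COP(=O)(O)O)[C@@H](O)[C@H]2O)c2nc(N)nc(O)c21` gives 15 uM, compound 2 `Nc1nc(O)c2c(n1)n(C1OC(CO)[C@@H](O)[C@H]1O)c(=O)n2CC(O)CO` gives 45 uM, and compound 3 `C=CCn1c(=O)n(CCCCCCCC)c2nc(N)nc(O)c21` gives 37 uM. Compound 2 thus carries the highest number of the three: its gap to compound 3 lies within the scatter, while its gap to compound 1 lies beyond it. Compound 4 `N#Cc1ccc(Cn2c(=O)n(C3OC(CO)[C@@H](O)[C@H]3O)c3nc(N)nc(O)c32)cc1` awaits measurement. It differs from compound 2 in one place: 4-cyanophenyl in place of 1,2-dihydroxyethyl on a saturated chain carbon bound to an aromatic nitrogen. Among the compounds with values here, no measured pair shows this change, so its effect cannot be read from the data. Because compound 3 gives 37 uM with no hydroxyl-bearing chain, no step beyond the scatter is expected in this assay in either direction. Compound 4 is estimated at 35 uM, with a range from 12 uM to 100 uM. The expected step of a 1.3-fold lower number from compound 2 to compound 4 (0.11 log units; within the scatter) is therefore small.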

Compound 4, concentration for half-maximal effect: 15 uM
Beside the measured number, compound 4's estimate is 2.3-fold (0.37 log units) above it; the range from low to high includes it.
By their numbers in this assay, from the lowest: compounds 1 and 4 (each within the scatter of the next); then compounds 3 and 2 (each within the scatter of the next).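

In this assay, within the data shown here, the change to 4-cyanophenyl in place of 1,2-dihydroxyethyl on a saturated chain carbon bound to an aromatic nitrogen brings a 3.0-fold lower number from compound 2 to compound 4 (0.48 log units; beyond the scatter) and is the only one-place step so far. It shows that this position responds to substitution and that its two hydrogen-bond donors can be given up without a higher number. Nothing measured here accounts for the step.

The compounds shown leave open whether the aromatic ring or the nitrile carries this step, which plain phenyl would help separate. As far as these compounds go, how a carboxylic acid or an amine in place of the nitrile would read also remains open.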